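The compounds below may be only part of what the source reports. "The series", "measured", "known", "first", "only" and "open" are said of these compounds alone.

Measured compounds:
Compound 1 `CCC1(Cc2ccccc2)OS(=O)(=O)C=C1OCc1ccc([N+](=O)[O-])cc1` gives >= 80000 nM in an ADME assay on HEL cells (Homo sapiens) for cytotoxicity, with a stated time of 3 days (on this read-out lower numbers stand for higher toxicity in this test and higher numbers for lower toxicity in this test), a limit rather than a number.
Compound 2 `CC1(Cc2ccccc2)OS(=O)(=O)C=C1OCc1ccccc1` gives > 400000 nM in this assay, again a limit.
Compound 3 `CCC1(Cc2ccccc2)OS(=O)(=O)C=C1OCCCCCCc1ccccc1` gives >= 20000 nM in this assay, also a limit.

Every value on this read-out is a limit, so none of the three compounds has a measured number, and compound 1 stands among them without a position that could be compared to the others. Compound 1 sits at the limit of >= 80000 nM in this assay, at which 1 of the 3 values shown sits, compound 2 at the limit of > 400000 nM in this assay, at which 1 of the 3 values shown sits, and compound 3 at the limit of >= 20000 nM in this assay, at which 1 of the 3 values shown sits. No pair of these compounds differs in one place only, so no measured step is available to guide an expectation.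

Compound 4 `CCC1(Cc2ccccc2)OS(=O)(=O)C=C1OCc1cccc(Cl)c1` differs from compound 1 in one place: 3-chlorophenyl in place of 4-nitrophenyl on a saturated chain carbon bound to an oxygen on an unsaturated carbon. Among the measured compounds shown here, with no measured step between any two of the compounds, there is no basis for expecting a shift beyond the usual scatter; the shared core carries a limit in every case so far, and compound 4 is expected to behave in the same way. The step from compound 1 to compound 4 is thus estimated as a step that the limit leaves unreadable from compound 1 to compound 4, essentially none. Compound 4 is therefore expected to give about 100000 nM, within a range of 30000 nM to 400000 nM, most likely as another limit.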

Compound 4, minimum cytotoxic concentration: >= 20000 nM
Compound 4 gave a limit, no number; the forecaster's own chance of this, stated with the estimate: 80%; the middle value lies beyond the limit too.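

In this assay, compound 1 and compound 4 each give a limit rather than a number, so the step between them cannot be read. The compounds shown leave open whether 3-chlorophenyl in place of 4-nitrophenyl changes toxicity to these cells at all.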